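Hydroxy for Fluoro on the Aromatic Ring

The compounds below may be only part of what the source reports. "The series", "measured", "known", "first", "only" and "open" are said of these compounds alone.

In an assay on HEK293 cells for inhibition of N-acylethanolamine-hydrolyzing acid amidase (Rattus norvegicus), read by LC-MS, with a stated time of 30 min (on this read-out lower numbers stand for stronger inhibition and higher numbers for weaker inhibition), compound 2 `O=C(CCCCCCc1ccc(F)cc1)N1CCCC1` gives 8000 nM, and compound 1 `O=C(CCCCCCc1ccccc1)N1CCCC1` gives 12900 nM, the two lying within the scatter of each other. Among the measured compounds shown here, the one measured step, a 1.6-fold lower number from compound 1 to compound 2 (0.21 log units; within the scatter), sits at the same aromatic position. Compound 3 `O=C(CCCCCCc1ccc(O)cc1)N1CCCC1` differs from compound 2 by hydroxy in place of fluoro on an aromatic carbon. For the measured compounds named here, no measured step involves a hydroxy group, so only the small fluoro step offers guidance, and it lay within the scatter. Compound 3 is therefore expected to give 10000 nM in this assay, between 3000 nM and 32000 nM. The expected step is a 1.3-fold higher number from compound 2 to compound 3 (0.10 log units; within the scatter), nothing beyond the scatter.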

Compound 3, half-maximal inhibitory concentration: 5600 nM
Beside the measured number, compound 3's estimate is 1.8-fold (0.25 log units) above it; measured number inside the range.
By their numbers in this assay, from the lowest: compounds 3, 2 and 1 (each within the scatter of the next, the first and the last beyond it).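

In this assay, among the compounds shown here, hydroxy in place of hydrogen on the aromatic carbon gives a 2.3-fold lower number from compound 1 to compound 3 (0.36 log units; beyond the scatter), the first change at this position to pass the scatter, though only modestly. Hydroxy in place of fluoro gives a 1.4-fold lower number from compound 2 to compound 3 (0.15 log units; within the scatter), so the two groups are not told apart at this position. Nothing available bears on why hydroxy differs from hydrogen here. As far as these compounds go, whether an amine or a methoxy group on the same aromatic carbon would move the number further remains open. So does whether the hydroxy step holds with a longer chain.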